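Swapping a guanidine-bearing side chain for isopropyl, twice

The source may report more compounds than this note shows. Statements on the series, on what has been measured and on what is new or still open speak of the compounds shown alone.

Measured compounds:
compound 1 `N=C(N)NCCC[C@H](NC(=O)CN(c1nc(Cl)nc2[nH]cnc12)C1CC1)C(=O)OCc1ccccc1` gives 23.2%
compound 2 `N=C(N)NCCC[C@H](NC(=O)CN(c1ncnc2c1ncn2C1CCCCO1)C1CC1)C(=O)OCc1ccccc1` gives 34.3%
compound 3 `CC(C)C[C@H](NC(=O)CN(c1nc(Cl)nc2[nH]cnc12)C1CC1)C(=O)OCc1ccccc1` gives 33.9%

These three were tested in a functional assay on the whole organism (Tail, strain ICR) with Mus musculus as the target, in the tail flick test, with a stated time of 30 min, at a dose of 25 umol/kg by the oral route; on this read-out higher numbers stand for a stronger effect at the one dose given and lower numbers for a weaker effect. Compound 1 and compound 3 share one core and differ by a group of 3 heavy atoms (3 carbon; no ring) in place of a group of 6 heavy atoms (3 carbon, 3 nitrogen; no ring), on a saturated chain carbon, two bonds along the chain from an amide-type nitrogen and a carbonyl carbon, a change that gave a number 10.7 percentage points higher from compound 1 to compound 3 (beyond the scatter). Compound 2 carries a different core; how the two cores differ is not broken down here. Compound 2 and compound 3 stand within the scatter of each other. Compound 4 `CC(C)C[C@H](NC(=O)CN(c1ncnc2c1ncn2C1CCCCO1)C1CC1)C(=O)OCc1ccccc1` is not yet measured and differs from compound 2 by the same change, (a group of 3 heavy atoms (3 carbon; no ring) in place of a group of 6 heavy atoms (3 carbon, 3 nitrogen; no ring), on a saturated chain carbon, two bonds along the chain from an amide-type nitrogen and a carbonyl carbon). Because compound 1 to compound 3 gave a number 10.7 percentage points higher from compound 1 to compound 3 (beyond the scatter), a step of similar size is expected here, although the other core makes this transfer uncertain, so the expected step from compound 2 to compound 4 is a number 7.7 percentage points higher from compound 2 to compound 4 (within the scatter). In this assay compound 4 is estimated at 42%, between 27% and 57%.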

Compound 4, a percentage reported as activity, at one dose (the size of the read-out at that dose, not a potency): 26.2%
Estimate against measurement, compound 4: 15.8 percentage points above; the whole stated range lies above it.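

On the core of compound 2, putting isopropyl in place of the guanidine-bearing side chain in this assay gave a number 8.1 percentage points lower from compound 2 to compound 4 (within the scatter), so on this core the swap shows no clear effect. Set beside the other core, the same change did not carry over: the same change on two cores in this assay, a number 10.7 percentage points higher (beyond the scatter) from compound 1 to compound 3 and a number 8.1 percentage points lower (within the scatter) from compound 2 to compound 4, 18.8 percentage points apart, beyond the scatter of two such steps. For the compounds shown here, this shows that the gain seen on one core cannot be assumed on the other, but with only one pair per core it does not show what makes the two cores differ.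

The compounds shown leave open whether another group at this place, such as an amine, a carboxylic acid or a longer chain, would behave alike on both cores. They also leave open how this swap would behave on a third core.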